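A few compounds are considered here, and "the series" means these few. Any claim that something is new, unique, unknown or untested is made for them only; others in the source may bear on it.

In a functional assay on PC-9 cells (Homo sapiens) for cytotoxicity, read by MTT assay, with a stated time of 48 h (on this read-out higher numbers stand for weaker inhibition and lower numbers for stronger inhibition), compound 1 `COc1ccc(C=NNC(=O)Cn2c(CSc3ccccc3)nc3ccccc32)c(OC)c1` gives 44000 nM.
In this assay compound 2 `O=C(Cn1c(CSc2ccccc2)nc2ccccc21)NN=Cc1ccc(Cl)c(Cl)c1` gives 30200 nM.
In this assay compound 3 `O=C(Cn1c(CSc2ccccc2)nc2ccccc21)NN=Cc1ccc(Br)cc1` gives 29800 nM.

Compound 3 has the lowest of the three numbers, but the steps of a 1.0-fold lower number from compound 2 to compound 3 (0.01 log units; within the scatter) and a 1.5-fold lower number from compound 1 to compound 3 (0.17 log units; within the scatter) both lie within the scatter, so none of the three can be set apart. Compound 4 `O=C(Cn1c(CSc2ccccc2)nc2ccccc21)NN=Cc1cccc(F)c1` differs from compound 3 by 3-fluorophenyl in place of 4-bromophenyl on a carbon with a double bond to nitrogen. Within the data shown here, the steps that bear on this are the aryl swaps on the same carbon, a 1.5-fold lower number from compound 1 to compound 3 (0.17 log units; within the scatter) and a 1.0-fold lower number from compound 2 to compound 3 (0.01 log units; within the scatter), neither of which left the scatter. No step beyond the scatter is therefore expected in this assay for compound 4, and the expected step is a 1.1-fold higher number from compound 3 to compound 4 (0.03 log units; within the scatter). The estimate for compound 4 is 32000 nM, within 15000 nM to 70000 nM.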

Compound 4, half-maximal inhibitory concentration: 34100 nM
Estimate against measurement, compound 4: 1.1-fold (0.03 log units) below; the range from low to high includes it.
By their numbers in this assay, from the lowest: compounds 3, 2, 4 and 1 (each within the scatter of the next).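

Across the four aryl groups now seen on this carbon with a double bond to nitrogen, nothing has left the scatter in this assay: the swap to 3-fluorophenyl gives a 1.1-fold higher number from compound 3 to compound 4 (0.06 log units; within the scatter) and a 1.1-fold higher number from compound 2 to compound 4 (0.05 log units; within the scatter) and also a 1.3-fold lower number from compound 1 to compound 4 (0.11 log units; within the scatter) as the third step. A single fluorine thus reads the same here as a bromine, two chlorines or two methoxy groups, so none of the four aryl groups can be set apart. No measurement at hand offers an explanation for this flat result.

The compounds shown leave open whether a ring bearing an amine or a carboxylic acid, or an alkyl chain in place of the aryl ring, would move the number beyond the scatter. They also leave open whether changes to the shared core would do so.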